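A few compounds are considered here, and "the series" means these few. Any claim that something is new, unique, unknown or untested is made for them only; others in the source may bear on it.

Measured in a physicochemical assay for lipophilicity, at pH 7.4; on this read-out higher numbers stand for higher lipophilicity and lower numbers for lower lipophilicity:

- Compound 1 `Cc1[nH]c2ccc(F)cc2c(=O)c1Br`: 1.61
- Compound 2 `CCc1c(C)[nH]c2cc(OC)c(F)cc2c1=O`: 1.2
- Compound 3 `CCc1c(C)[nH]c2cc(OC)c(Cl)cc2c1=O`: 2.43

Compound 3, at 2.43, has the highest of the three values in this assay, and its gaps to compound 1 and compound 2 both lie beyond the scatter. Compound 4 `CCc1c(C)[nH]c2cc(OC)c(Br)cc2c1=O` has not yet been measured. Its structural change from compound 3 is bromo in place of chloro on an aromatic carbon, ortho to a methoxy group.

Among the measured compounds shown here, only one measured step bears on this change: a number 1.23 log units higher from compound 2 to compound 3 (beyond the scatter), a large step beyond the scatter for chloro in place of fluoro on an aromatic carbon. For the measured compounds named here, no measured pair shows bromo in place of chloro, so the size of this exchange remains uncertain. A further move upward in this assay is expected, though a much smaller one that may not clear the scatter. The expected change is a number 0.27 log units higher from compound 3 to compound 4 (within the scatter). For compound 4 the estimated value is 2.7, with an expected range from 2.25 to 3.15.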

Compound 4, distribution coefficient: 1.7
Compound 4: middle estimate off by 1.00 log units, on the high side; the measured number lies below the stated range.
By their numbers in this assay, from the lowest: compound 2; then compounds 1 and 4 (each within the scatter of the next); then compound 3.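

In this assay the halogens on this aromatic carbon, ortho to a methoxy group, do not climb steadily with the size of the atom: bromo in place of chloro gives a number 0.73 log units lower from compound 3 to compound 4 (beyond the scatter) while bromo in place of fluoro gives a number 0.50 log units higher from compound 2 to compound 4 (beyond the scatter) as the second step of this small series. Among these three compounds, which differ in this one place only, chloro thus carries the highest number, and bromo stands under chloro but over fluoro. Nothing at hand explains why the direction turns at bromo.

Going by these compounds, whether the same order would hold on a core lacking the methoxy group remains open. So does the place of an iodo, a nitrile or a trifluoromethyl group on this carbon in this assay relative to the three halogens shown.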